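Chloro substitution carried from amide to ester series

A few compounds are considered here, and "the series" means these few. Any claim that something is new, unique, unknown or untested is made for them only; others in the source may bear on it.

Compound 1 `CS(=O)(=O)NCCN1CCC(CNC(=O)c2cccc3[nH]cnc23)CC1` is the unsubstituted parent. In an assay on membranes from striatum for binding affinity to 5-hydroxytryptamine receptor 4 (Rattus norvegicus) (a higher number here means a weaker inhibitor, a lower number a stronger inhibitor), compound 1 gives 11.4 nM. Compound 2 `CS(=O)(=O)NCCN1CCC(CNC(=O)c2cc(Cl)cc3[nH]cnc23)CC1` carries the change (chloro in place of hydrogen on an aromatic carbon); in this assay compound 2 gives 0.11 nM, so the step of a 100-fold lower number from compound 1 to compound 2 (2.02 log units; beyond the scatter) is recorded. Compound 3 `CS(=O)(=O)NCCN1CCC(COC(=O)c2cccc3[nH]cnc23)CC1` differs from compound 1 in the core; the difference between the two cores is not broken down here. In this assay compound 3 gives 26.1 nM, a number that stands above that of compound 1 by more than the usual scatter. Compound 4 `CS(=O)(=O)NCCN1CCC(COC(=O)c2cc(Cl)cc3[nH]cnc23)CC1` has not been measured; it relates to compound 3 as compound 2 relates to compound 1, through (chloro in place of hydrogen on an aromatic carbon), the same change at the same place. Among the measured compounds shown here, the only precedent is a single pair, so the expectation rests on one measured step. For compound 4 the step of an 87-fold lower number from compound 3 to compound 4 (1.94 log units; beyond the scatter) in this assay is expected because the step of a 100-fold lower number from compound 1 to compound 2 (2.02 log units; beyond the scatter) was large and the change is made at the same place. Compound 4 is therefore estimated at 0.3 nM in this assay, with a range from 0.08 nM to 1.5 nM.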

Compound 4, inhibition constant: 2.3 nM
Estimate against measurement, compound 4: 7.7-fold (0.88 log units) below; the whole stated range lies below it.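

On the core of compound 3 in this assay, chloro in place of hydrogen on an aromatic carbon gives an 11-fold lower number from compound 3 to compound 4 (1.05 log units; beyond the scatter) and so runs in the same direction as on the core of compound 1. The size of the step does not carry over unchanged from one core to the other: the same change on two cores in this assay, a 100-fold lower number (2.02 log units; beyond the scatter) from compound 1 to compound 2 and an 11-fold lower number (1.05 log units; beyond the scatter) from compound 3 to compound 4, 9.1-fold (0.96 log units) apart, beyond the scatter of two such steps. These two pairs show that the direction held on both cores, but they do not explain the gap in size and give no rule for the size of this step on any further core.

The compounds shown hold only hydrogen and chloro at this place, so the effect of a fluoro, bromo or methoxy group there remains open. Also open, on these data alone, is whether the step would keep its direction on a core carrying a longer chain between the carbonyl and the rest of the molecule.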